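Nitro to Hydrogen on the Aryl Urea of Compound 2

The source may report more compounds than this note shows. Statements on the series, on what has been measured and on what is new or still open speak of the compounds shown alone.

Measured compounds:
compound 1 `O=C(Nc1cccc(C(F)(F)F)c1)N[C@H]1CC[C@H](Oc2ccc(C(F)(F)F)cc2)CC1` gives 460 nM
compound 2 `O=C(Nc1ccc([N+](=O)[O-])cc1)N[C@H]1CC[C@H](Oc2ccc(F)cc2)CC1` gives 2300 nM

Both compounds were tested in a functional assay on CRL2813 cells (Homo sapiens) for cytotoxicity, read by sulforhodamine B assay, with a stated time of 5 days; on this read-out higher numbers stand for weaker inhibition and lower numbers for stronger inhibition. Compound 2 stands with the highest of the two numbers; compound 1 lies well below it, a gap beyond the usual scatter. Within the data shown here, since no single-change step connects them, the two values show only that compound 2 is the weaker of the pair.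

Compound 3 `O=C(Nc1ccccc1)N[C@H]1CC[C@H](Oc2ccc(F)cc2)CC1` differs from compound 2 by hydrogen in place of nitro on an aromatic carbon. No measured step of this kind exists among the compounds shown, so the effect must be judged without precedent. The step of a 1.5-fold higher number from compound 2 to compound 3 (0.18 log units; within the scatter) is expected to be small, toward a weaker number, and possibly not beyond the scatter. Compound 3 is therefore estimated at 3500 nM in this assay, with a range from 1200 nM to 10000 nM.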

Compound 3, half-maximal inhibitory concentration: 20000 nM
Compound 3: middle estimate off by 5.7-fold (0.76 log units), on the low side, and the stated range ends below it.
By their numbers in this assay, from the lowest: compound 1; then compound 2; then compound 3.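

In this assay, among these compounds, the change from 4-nitrophenyl to phenyl gives an 8.7-fold higher number from compound 2 to compound 3 (0.94 log units; beyond the scatter), the first step in this set that isolates a single place. With the rest of compound 2 held fixed, it shows that the group on this aromatic carbon, para to a large group, has a clear bearing on the read-out, and that removing nitro in favour of hydrogen leads to weaker inhibition. Nothing at hand bears on the reason for this loss.

As far as these compounds go, whether a nitrile, an amine or a carboxylic acid on this same carbon would keep the number near that of compound 2 or lose as much as compound 3 stays open. Compound 1 differs from the other two in more than one place, so the effect of its trifluoromethyl groups cannot be read.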